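This account rests on a few compounds, and the source may have more. Where it says the series, first, only, none or still open, it means among the compounds named here.

Series notes. Compound 1 `CC(c1ccc(-c2ccsc2)nc1)n1ccnc1` and compound 2 `c1cn(C(c2ccc(-c3ccsc3)nc2)C2CC2)cn1` share one core; compound 3 `CC(c1ccc(-c2cccc3ccccc23)nc1)n1ccnc1` and the unmeasured compound 4 `c1ccc2c(-c3ccc(C(C4CC4)n4ccnc4)cn3)cccc2c1` share another. The difference between the two cores is not broken down here. In an in vitro assay on V79MZh cells for inhibition of cytochrome P450 11B1, mitochondrial (Homo sapiens) (on this read-out lower numbers stand for stronger inhibition and higher numbers for weaker inhibition), compound 1 gives 21 nM, compound 2 gives 11 nM and compound 3 gives 60 nM. The change from compound 1 to compound 2 is cyclopropyl in place of methyl on a saturated chain carbon bound to an aromatic carbon and an aromatic nitrogen, and it made a 1.9-fold lower number from compound 1 to compound 2 (0.28 log units; within the scatter). The same change, (cyclopropyl in place of methyl on a saturated chain carbon bound to an aromatic carbon and an aromatic nitrogen), is made from compound 3 to compound 4. In this assay a step of about a 1.9-fold lower number from compound 3 to compound 4 (0.27 log units; within the scatter) is expected, set beside a 1.9-fold lower number from compound 1 to compound 2 (0.28 log units; within the scatter); this rests on that single measured pair, and the core is different, so the carry-over is uncertain. Compound 4 is estimated at 32 nM, with a range from 15 nM to 70 nM.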

Compound 4, half-maximal inhibitory concentration: 151 nM
For compound 4 the middle estimate is 4.7-fold (0.67 log units) below the measured one, outside the stated range (above it).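

In this assay, cyclopropyl in place of methyl does not carry over as a constant step between these two cores: the same change on two cores in this assay, a 1.9-fold lower number (0.28 log units; within the scatter) from compound 1 to compound 2 and a 2.5-fold higher number (0.40 log units; beyond the scatter) from compound 3 to compound 4, 4.8-fold (0.68 log units) apart, beyond the scatter of two such steps. On the second core the measured result is a 2.5-fold higher number from compound 3 to compound 4 (0.40 log units; beyond the scatter), so the step on the core of compound 1 gives no reliable guide here. This rests on one pair per core and does not show what in the cores separates the two steps, nor how the change would behave on any further core.

From the compounds shown here alone, whether ethyl or isopropyl on the saturated chain carbon bound to an aromatic carbon and an aromatic nitrogen would follow either step remains open. Also open, going by these compounds, is which step, if either, a third core would resemble.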